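Phenyl to 4-methylphenyl on the shared core

The source may hold more compounds than are shown below. What is called first, only, known or untested is meant among the compounds shown, and "the series" means these compounds.

Compound 3 `Nc1cccc(-c2cn3nc(-c4ccccc4)sc3n2)c1` is the anchor of this small set. In a functional assay on FM3A cells (Mus musculus) for inhibition, read by cell counting, with a stated time of 2 days (a higher number here means a weaker inhibitor, a lower number a stronger inhibitor), compound 3 gives 14000 nM, the lowest of the two numbers reported; its nearest neighbour is compound 2 `COc1ccc(-c2nn3cc(-c4cccc(N)c4)nc3s2)cc1`, which in this assay gives 74000 nM, and the step of a 5.3-fold lower number from compound 2 to compound 3 (0.72 log units; beyond the scatter) lies beyond the scatter. Compound 1 `Nc1cccc(-c2cn3nc(-c4cccs4)sc3n2)c1` is reported in this assay only as a limit, > 250000 nM (the limit of > 250000 nM in this assay, at which 1 of the 3 values shown sits). The step of an at least 17-fold lower number from compound 1 to compound 3 (1.25 log units; beyond the scatter) is the largest change seen here.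

Compound 4 `Cc1ccc(-c2nn3cc(-c4cccc(N)c4)nc3s2)cc1` differs from compound 3 by methyl in place of hydrogen on an aromatic carbon. Among the measured compounds shown here, the one measured step that bears on this place is a 5.3-fold lower number from compound 2 to compound 3 (0.72 log units; beyond the scatter), read the other way: a methoxy entering where the methyl now enters raised the number modestly. Taking that as the guide, a modest rise in this assay is expected for compound 4, as a 2.5-fold higher number from compound 3 to compound 4 (0.40 log units; beyond the scatter). Compound 4 is therefore estimated at 35000 nM, within a range of 10000 nM to 120000 nM.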

Compound 4, half-maximal inhibitory concentration: 5800 nM
Compound 4: middle estimate off by 6.0-fold (0.78 log units), on the high side; measured number below the stated range.
By their numbers in this assay, from the lowest: compound 4; then compound 3; then compound 2. At a limit, above all of these: compound 1.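

Among the compounds shown here, at the place on the six-membered aromatic ring para to a large group, the earlier compounds showed only that methoxy goes with a higher number than hydrogen, whereas methyl goes with a lower one (a 2.4-fold lower number from compound 3 to compound 4 (0.38 log units; beyond the scatter)), so the direction of the change in this assay depends on the group that enters. The two entering groups therefore lie far apart at this one place (a 13-fold lower number from compound 2 to compound 4 (1.11 log units; beyond the scatter)). The change from thiophen-2-yl to 4-methylphenyl also gives a large step (an at least 43-fold lower number from compound 1 to compound 4 (1.63 log units; beyond the scatter)), but its true size cannot be read, as compound 1 stands only as a limit: the limit of > 250000 nM in this assay, at which 1 of the 4 values shown sits.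

The compounds shown leave open whether an ethyl, a chlorine or an amine at this same place would track methyl or methoxy. They also do not tell why methyl and methoxy part in this way.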